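Three Measured Analogues and One Awaiting Its Cytotoxicity Number

This account rests on a few compounds, and the source may have more. Where it says the series, first, only, none or still open, it means among the compounds named here.

Compound 2 `COc1cc2ncnc(NNC(=S)NC(=O)c3ccc(Cl)cc3)c2cc1OC` gives 7530 nM in a functional assay on CNE-2 cells (Homo sapiens) for cytotoxicity, read by MTT assay, with a stated time of 72 h (a lower number here means a stronger inhibitor, a higher number a weaker inhibitor), the second highest of three numbers: compound 1 `O=C(NC(=S)NNc1ncnc2ccccc12)c1ccccc1F` gives 4610 nM, within the scatter of compound 2, while compound 3 `COc1ccccc1C(=O)NC(=S)NNc1ncnc2ccccc12` gives 15700 nM, beyond it. Among the measured compounds shown here, the one measured step, a 3.4-fold higher number from compound 1 to compound 3 (0.53 log units; beyond the scatter), changes the group on the ring joined to the carbonyl. Compound 4 `COc1cc2ncnc(NNC(=S)NC(=O)c3ccccc3C)c2cc1OC` differs from compound 2 by 2-methylphenyl in place of 4-chlorophenyl on a carbonyl carbon. That change also alters this ring, yet neither the departing nor the entering group appears in the measured step, so it bears only loosely. Guided by a 3.4-fold higher number from compound 1 to compound 3 (0.53 log units; beyond the scatter), a modest weakening or no change beyond the scatter is expected for compound 4, a 1.3-fold higher number from compound 2 to compound 4 (0.12 log units; within the scatter). Compound 4 is estimated at 10000 nM, between 4000 nM and 25000 nM.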

Compound 4, half-maximal inhibitory concentration: 10500 nM
Compound 4: middle estimate off by 1.1-fold (0.02 log units), on the low side; the measured number falls inside the stated range.
By their numbers in this assay, from the lowest: compounds 1, 2, 4 and 3 (each within the scatter of the next, the first and the last beyond it).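

In this assay, replacing 4-chlorophenyl with 2-methylphenyl on a carbonyl carbon gives a result within the scatter (a 1.4-fold higher number from compound 2 to compound 4 (0.14 log units; within the scatter)). Here, then, a change to the ring on the carbonyl leaves the number essentially in place, whereas the earlier change on that ring, on the core of compound 1, went beyond the scatter (a 3.4-fold higher number from compound 1 to compound 3 (0.53 log units; beyond the scatter)). No measurement is available to explain this. The compounds shown leave open how an amine or a carboxylic acid on this ring would read. They also leave open whether 2-methylphenyl and 4-chlorophenyl would stay within the scatter of each other on the core of compound 1.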